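Compound 2 and its 5-chloropyridin-3-yl counterpart

A few compounds are considered here, and "the series" means these few. Any claim that something is new, unique, unknown or untested is made for them only; others in the source may bear on it.

In a physicochemical assay for metabolic stability, read by HPLC (on this read-out higher numbers stand for a longer-lived compound and lower numbers for a shorter-lived compound), compound 1 (`O=c1ccn([C@H]2CC[C@@H](COP(=O)(O)Oc3ccccc3)O2)c(=O)[nH]1`) gives 25.1 h as its reading. Compound 3 (`Nc1ncnc2c1ncn2[C@H]1CC[C@@H](COP(=O)(O)Oc2ccccc2)O1`) gives 36.1 h as its reading. Compound 2 (`Cc1ccc(OP(=O)(O)OC[C@H]2O[C@@H](n3cc(C)c(=O)[nH]c3=O)C[C@@H]2N=[N+]=[N-])cn1`) gives 28.9 h and lies within the scatter of both compound 1 and compound 3, so these three numbers cannot be ranked.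

Compound 4 (`Cc1cn([C@H]2C[C@H](N=[N+]=[N-])[C@@H](COP(=O)(O)Oc3cncc(Cl)c3)O2)c(=O)[nH]c1=O`) has not yet been measured and differs from compound 2 in one place: 5-chloropyridin-3-yl in place of 6-methylpyridin-3-yl on an oxygen. Here 5-chloropyridin-3-yl stands in place of 6-methylpyridin-3-yl on an oxygen whose other neighbour is phosphorus. Going by the values given here, no measured pair shows this exchange, so the data give no direct guide to its size in this assay and no firm direction. The expectation rests on compound 1 (25.1 h) and compound 3 (36.1 h), which differ from compound 2 in more than one place yet remain within the scatter of it. The estimated change is a 1.3-fold lower number from compound 2 to compound 4 (0.10 log units; within the scatter) and it is expected to stay within the scatter. For compound 4 the estimated half-life is 23 h with an expected range from 11 h to 42 h in repeated measurements.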

Compound 4, half-life: 7.27 h
Compound 4: middle estimate off by 3.2-fold (0.50 log units), on the high side; measured number below the stated range.
By their numbers in this assay, from the lowest: compound 4; then compounds 1, 2 and 3 (each within the scatter of the next).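

In this assay, replacing 6-methylpyridin-3-yl with 5-chloropyridin-3-yl on an oxygen whose other neighbour is phosphorus gives a 4.0-fold lower number from compound 2 to compound 4 (0.60 log units; beyond the scatter), a step that lies beyond the scatter. This shows that the group on this oxygen can alter the half-life with the rest of the structure unchanged, which compound 1 and compound 3 could not show, as each differs from compound 2 in more than one place. The data offer no measurement that accounts for the size or direction of this step.

The step exchanges both the substituent and its numbered place on the ring, so the compounds shown cannot separate the two. A 5-methylpyridin-3-yl or 6-chloropyridin-3-yl group would address that question, while a 5-fluoropyridin-3-yl group would test whether another halogen behaves in the same way.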